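The source may report more compounds than this note shows. Statements on the series, on what has been measured and on what is new or still open speak of the compounds shown alone.

Measured compounds:
compound 1 `COc1ccc2c(c1)OC(c1cc(OC)c(OC)c(OC)c1)C(CO)=C2` — > 50000 nM
compound 2 `COc1ccc2c(c1)OC(c1cc(OC)c(OC)c(OC)c1)C(C(=O)N1CCCCC1)=C2` — > 50000 nM
compound 3 `COc1ccc2c(c1)OC(c1cc(OC)c(OC)c(OC)c1)C(/C=N/O)=C2` — 14100 nM

In a functional assay for inhibition of nuclear factor NF-kappa-B complex (Homo sapiens) (a lower number here means a stronger inhibitor, a higher number a weaker inhibitor), compound 1 gives > 50000 nM, which is a limit of the assay and not a number. Compound 2 likewise gives > 50000 nM, again a limit. Compound 3 gives 14100 nM. Compound 1 thus stands at the limit of > 50000 nM in this assay, at which 2 of the 3 values shown sit, and only compound 3 yields a number.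

Compound 4 `COc1ccc2c(c1)OC(c1cc(OC)c(OC)c(OC)c1)C(C(N)=O)=C2` differs from compound 1 by carbamoyl in place of hydroxymethyl on a double-bonded ring carbon.

Going by the values given here, two measured steps bear on this change. The step of an at least 3.5-fold lower number from compound 1 to compound 3 (0.54 log units; beyond the scatter) shows that a group of 3 heavy atoms (1 carbon, 1 nitrogen, 1 oxygen; no ring) in place of hydroxymethyl on the double-bonded ring carbon brings the number below the limit. The step that the two limits leave unreadable from compound 1 to compound 2 shows that a (piperidin-1-yl)carbonyl in the same place does not, and an at least 3.5-fold lower number from compound 2 to compound 3 (0.54 log units; beyond the scatter) separates the two. Carbamoyl matches compound 3 in atom count and matches compound 2 in carrying a carbonyl, so a modest step toward a lower number is expected for compound 4, but it may not clear the limit.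

Compound 4 is expected to show an at least 1.6-fold lower number from compound 1 to compound 4 (0.22 log units; that floor lies within the scatter). For compound 4 the estimate in this assay is 30000 nM, between 8000 nM and 100000 nM.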

Compound 4, half-maximal inhibitory concentration: > 50000 nM
Compound 4: a limit, no number; the forecaster's own chance of this, stated with the estimate: 45%; middle value at least 1.6-fold (0.22 log units) away from the limit.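

In this assay, carbamoyl has the same heavy-atom count as the group it replaces in compound 3, yet the change gives an at least 3.5-fold higher number from compound 3 to compound 4 (0.54 log units; beyond the scatter), so at this double-bonded ring carbon that count alone does not bring the number under the limit. The steps joining compound 4 to compound 1 and to compound 2 cannot be read, as each has a limit at both ends, so amino in place of piperidin-1-yl on the carbonyl carbon shows no readable effect. Among the groups shown at this position, hydroxymethyl and both carbonyl-bearing groups stay at the limit, and only compound 3 yields a number: the limit of > 50000 nM in this assay, at which 3 of the 4 values shown sit.

Going by these compounds, the order of compound 1, compound 2 and compound 4 relative to one another stays unknown, with all three resting on a limit. Also open, on these data alone, is whether a nitrile, a carboxylic acid or an aminomethyl group on the same ring carbon would yield a number in this assay, and so whether compound 3 stands alone among groups of this size.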